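The source may hold more compounds than are shown below. What is called first, only, known or untested is meant among the compounds shown, and "the series" means these compounds.

Measured compounds:
- compound 1 `CCN(C(=O)COc1ccc(C)cc1)C(C)c1cccs1`: "not active" (no number reported)
- compound 2 `CCC(C)N(Cc1cccs1)C(=O)COc1ccc(C)cc1`: 2000 nM

Within the data shown here, in an assay on HEK293 cells for agonist activity at transient receptor potential cation channel subfamily M member 8 (Homo sapiens), read by fluorescence and calcium flux, with a stated time of 15 min (a lower number here means that less compound is needed, a higher number that more compound is needed for the effect), compound 2 gives the only number reported; compound 1 is recorded as "not active" (no number reported) without a number. Compound 3 `Cc1ccc(OCC(=O)N(Cc2cccs2)c2c[nH]nc2C)cc1` has not yet been measured. It differs from compound 2 by 3-methyl-1H-pyrazol-4-yl in place of sec-butyl on an amide-type nitrogen. Among the measured compounds shown here, no measured pair shows what such a change does in this assay, so the direction is open. A small step is expected, within or just beyond the usual scatter, with weaker activity somewhat more likely. Compound 3 is expected to give 3000 nM, between 800 nM and 12000 nM, an estimated step of a 1.5-fold higher number from compound 2 to compound 3 (0.18 log units; within the scatter).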

Compound 3, half-maximal effective concentration: 0.4 nM
For compound 3 the middle estimate is 7500-fold (3.88 log units) above the measured one, and the stated range ends above it.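

In this assay, the group on the amide-type nitrogen proves to be a sensitive point, since 3-methyl-1H-pyrazol-4-yl in place of sec-butyl gives a 5000-fold lower number from compound 2 to compound 3 (3.70 log units; beyond the scatter) in a single change. The entering group brings an aromatic ring and a hydrogen-bond donor and acceptor, where sec-butyl has none of these, though the data cannot say which of these features matters. No supporting measurement explains the size of this step. Going by these compounds, whether phenyl, or 1H-pyrazol-4-yl without its methyl, would behave the same way on this nitrogen stays open.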